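Compound 3 to compound 4: a furan-2-yl exchange

The compounds below may be only part of what the source reports. "The series", "measured", "known", "first", "only" and "open" are said of these compounds alone.

Values in an ADME assay on HepG2 cells (Homo sapiens) for cytotoxicity, read by CellTiter-Glo and resazurin assay, with a stated time of 72 h (a higher number here means that more compound is needed for the effect, a lower number that less compound is needed), each one a limit:
compound 1 `CCOC(=O)CCCCCOc1cccc(CN(C(=O)c2ccc(-c3cccc(N(C)C)c3)cc2)C(C)C)c1`: > 26000 nM
compound 2 `CCOC(=O)CCCCCOc1cccc(CN(C(=O)c2ccc(-c3ccc4ccccc4c3)cc2)C(C)C)c1`: > 26000 nM
compound 3 `CCOC(=O)CCCCCOc1cccc(CN(C(=O)c2ccc(-c3cnc(OC)nc3OC)cc2)C(C)C)c1`: > 26000 nM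

Compound 3 stands at > 26000 nM in this assay, and this is a limit, not a number. The same holds for the whole measured set, which shows the limit of > 26000 nM in this assay, at which 3 of the 3 values shown sit, and nothing else.

Compound 4 `CCOC(=O)CCCCCOc1cccc(CN(C(=O)c2ccc(-c3ccco3)cc2)C(C)C)c1` differs from compound 3 as follows: furan-2-yl in place of 2,4-dimethoxypyrimidin-5-yl on an aromatic carbon. In words, this is furan-2-yl in place of 2,4-dimethoxypyrimidin-5-yl on an aromatic carbon.

The measured steps that bear on it are the other exchanges on that aromatic carbon: a step that the two limits leave unreadable from compound 1 to compound 2, a step that the two limits leave unreadable from compound 1 to compound 3 and a step that the two limits leave unreadable from compound 2 to compound 3. None of them has a readable size, and no exchange in the set gives a number in this assay. No step beyond the scatter is therefore expected, and no direction can be given. The expected step is a step that the limit leaves unreadable from compound 3 to compound 4 as an estimate.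

Compound 4 is expected near 30000 nM in this assay, with an estimated range of 14000 nM to 60000 nM, and will most likely be reported only as a limit.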

Compound 4, half-maximal effective concentration: > 26000 nM
Compound 4: a limit, no number; the forecaster's own chance of this, stated with the estimate: 85%; the middle value is on the limit's open side.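

In this assay compound 4 gives > 26000 nM as a limit, not a number. Within the data shown here, no step to compound 4 can be read from compound 1, compound 2 or compound 3, and the set offers only one limit: the limit of > 26000 nM in this assay, at which 4 of the 4 values shown sit.

The concentration at which any of these compounds would reach the half-maximal effect in this assay stays open.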